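The compounds below may be only part of what the source reports. "The series", "measured", "known", "first", "only" and "open" are said of these compounds alone.

Compound 3 `CCC/C=C\C(=O)Nc1cc(Nc2nccc(-c3cn(C)c4ccc(F)cc34)n2)c(OC)cc1N(C)CCN(C)C` sits second highest among three measured numbers in a functional assay on NCI-H1975 cells (Homo sapiens) for antiproliferative activity, read by MTT assay, with a stated time of 72 h; a lower number here means a stronger inhibitor, a higher number a weaker inhibitor: compound 3 gives 2730 nM. Its nearest neighbour is compound 1 `CCC/C=C\C(=O)Nc1cc(Nc2nccc(-c3cn(C)c4ccccc34)n2)c(OC)cc1N(C)CCN(C)C`, which in this assay gives 1220 nM, and the change a 2.2-fold higher number from compound 1 to compound 3 (0.35 log units; beyond the scatter) came from a fluoro in place of hydrogen on an aromatic carbon. Compound 2 `COc1cc(N(C)CCN(C)C)c(NC(=O)/C=C\C(C)C)cc1Nc1nccc(-c2cn(C)c3ccc(F)cc23)n1` gives 7360 nM in this assay, and the change a 2.7-fold lower number from compound 2 to compound 3 (0.43 log units; beyond the scatter) came from a propyl in place of isopropyl on a double-bonded chain carbon bound to a double-bonded chain carbon.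

Compound 4 `CCC/C=C\C(=O)Nc1cc(Nc2ncc(C#N)c(-c3cn(C)c4ccc(F)cc34)n2)c(OC)cc1N(C)CCN(C)C` differs from compound 3 by cyano in place of hydrogen on an aromatic carbon. Within the data shown here, neither measured step involves a cyano group or this position of the core, so no measured step bears directly on this change; both measured steps were modest in size, which is the only guide available. On that basis, the step of a 2.3-fold lower number from compound 3 to compound 4 (0.36 log units; beyond the scatter) from compound 3 to compound 4 is expected to be modest and its direction uncertain. Compound 4 is therefore estimated to give 1200 nM in this assay, within a range from 400 nM to 4000 nM.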

Compound 4, half-maximal inhibitory concentration: 2420 nM
Compound 4: middle estimate off by 2.0-fold (0.30 log units), on the low side; the measured number falls inside the stated range.
By their numbers in this assay, from the lowest: compounds 1, 4 and 3 (each within the scatter of the next, the first and the last beyond it); then compound 2.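

Placing a cyano group on this aromatic carbon of the six-membered ring with 2 nitrogen, ortho to the 5-fluoro-1-methyl-1H-indol-3-yl group, gives a result in this assay that cannot be told apart from that with hydrogen, with a 1.1-fold lower number from compound 3 to compound 4 (0.05 log units; within the scatter) for this swap. The fluoro-for-hydrogen and propyl-for-isopropyl steps both lie beyond the scatter, so this is the only single change shown that stays within it, and this carbon can carry the added two heavy atoms with no measurable difference here. Nothing available explains this result.

On these data alone, the cyano group appears here only alongside the fluoro group, so its effect on the hydrogen-bearing indole of compound 1 remains open. Also open, as far as these compounds go, is what an amine, a carboxylic acid or a chlorine atom on this same carbon would give.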